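Methoxy to hydroxy in a cytotoxicity series

This account rests on a few compounds, and the source may have more. Where it says the series, first, only, none or still open, it means among the compounds named here.

Measured in an ADME assay on HEK293 cells (Homo sapiens) for cytotoxicity, read by MTT assay, with a stated time of 72 h (a higher number here means a weaker inhibitor, a lower number a stronger inhibitor), so far:
compound 1 `Cc1cc(/C=C/c2ccc(O)c(O)c2)on1` gives 13000 nM
compound 2 `COc1ccc(/C=C/c2cc(C)no2)cc1` gives 58300 nM

Compound 2, at 58300 nM in this assay, holds the higher of the two numbers, beyond the scatter of compound 1. Compound 3 `Cc1cc(/C=C/c2ccc(O)cc2)on1` has hydrogen in place of methyl on an oxygen on an aromatic ring and so goes from methoxy to hydroxy. Among the compounds with values here, no measured pair shows this change alone. Compound 1, which carries no methoxy, gives 13000 nM and suggests a lower number. The expected change, a 2.1-fold lower number from compound 2 to compound 3 (0.32 log units; beyond the scatter) in this assay, is a modest one near the edge of the scatter. For compound 3 the estimate is 28000 nM with an expected range from 11000 nM to 65000 nM in this measurement.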

Compound 3, half-maximal inhibitory concentration: 50200 nM
Compound 3: middle estimate off by 1.8-fold (0.25 log units), on the low side; low and high end bracket the measured number.
By their numbers in this assay, from the lowest: compound 1; then compounds 3 and 2 (each within the scatter of the next).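

The step for methoxy to hydroxy, a 1.2-fold lower number from compound 2 to compound 3 (0.06 log units; within the scatter) in this assay, shows that this exchange on the aromatic ring has no readable effect on its own. The step for hydrogen in place of hydroxy on an aromatic carbon, a 3.9-fold higher number from compound 1 to compound 3 (0.59 log units; beyond the scatter), is the one that lies beyond the scatter, so the hydroxy present in compound 1 and absent from compound 3 marks the difference in this pair. Nothing available here accounts for either step. The compounds shown leave open how an amine or a carboxylic acid on that aromatic carbon would read in this assay.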